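This account rests on a few compounds, and the source may have more. Where it says the series, first, only, none or still open, it means among the compounds named here.

Working notes on the series. Compound 2 `COc1cc(-n2cc(-c3ccc(Cl)cc3)[nH]c2=O)cc(OC)c1OC`, compound 1 `COc1ccc(-n2cc(-c3ccc(Cl)cc3)[nH]c2=S)cc1Cl` and compound 3 `COc1ccc(-n2cc(-c3ccc(OC)c(OC)c3)[nH]c2=S)cc1Cl` share one core and have all been run in a functional assay on DU-145 cells (Homo sapiens) for antiproliferative activity; a lower number here means a stronger inhibitor of growth, a higher number a weaker inhibitor of growth. In this assay compound 2 gives 63100 nM, and compound 1 gives 39800 nM; the two sit within the usual scatter of each other, so neither can be placed above the other. Compound 3 gives > 100000 nM, which is a limit of this assay and not a number (the limit of > 100000 nM in this assay, at which 1 of the 3 values shown sits). Compound 4 `COc1cc(-n2cc(-c3ccccc3)[nH]c2=O)cc(OC)c1OC` is the next to be measured; it differs from compound 2 by hydrogen in place of chloro on an aromatic carbon. For the measured compounds named here, no measured pair shows this change, so in this assay no step beyond the scatter is expected in either direction, with a slightly weaker inhibitor thought more likely than a stronger one. For compound 4 the expected value in this assay is 80000 nM, between 30000 nM and 200000 nM. The step of a 1.3-fold higher number from compound 2 to compound 4 (0.10 log units; within the scatter) is the one expected.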

Compound 4, concentration for 50% growth inhibition: 1580 nM
Estimate against measurement, compound 4: 51-fold (1.70 log units) above; measured number below the stated range.
By their numbers in this assay, from the lowest: compound 4; then compounds 1 and 2 (each within the scatter of the next). At a limit, above all of these: compound 3.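

For the compounds shown here, the change 4-chlorophenyl to phenyl gives a 40-fold lower number from compound 2 to compound 4 (1.60 log units; beyond the scatter) in this assay, the first step beyond the scatter. This position, para to a large group, therefore strongly affects growth inhibition in this pair, and hydrogen is clearly preferred to chloro here. The data at hand give no explanation for the size of this step.

From the compounds shown here alone, the step rests on compounds 2 and 4 alone, so its effect on compounds with sulfur in place of the carbonyl oxygen remains unknown. Going by these compounds, whether fluoro, methyl or an amine at this position would match hydrogen also remains open.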